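This account rests on a few compounds, and the source may have more. Where it says the series, first, only, none or still open, it means among the compounds named here.

For the measured compounds named here, the three compounds measured so far share one core, a sugar-bearing ring system carrying an ester side chain, and all were tested in a functional assay on SK-BR-3 cells (Homo sapiens) for antiproliferative activity, read by MTT assay, with a stated time of 72 h; on this read-out higher numbers stand for weaker inhibition and lower numbers for stronger inhibition. Compound 1 `C/C=C1/[C@H](O[C@@H]2O[C@H](COC(C)=O)[C@@H](OC(C)=O)[C@H](OC(C)=O)[C@H]2OC(C)=O)OC=C(C(=O)O)[C@H]1CC(=O)OC` gives a result that is only a limit of this assay, > 20000 nM. Compound 2 `C/C=C1/[C@H](O[C@@H]2O[C@H](COC(C)=O)[C@@H](OC(C)=O)[C@H](OC(C)=O)[C@H]2OC(C)=O)OC=C(C(=O)OC)[C@H]1CC(=O)OC`, in which a methyl replaces hydrogen on an oxygen next to a carbonyl group, likewise gives only a limit, > 15000 nM. Compound 3 `C/C=C1/[C@H](O[C@@H]2O[C@H](CO)[C@@H](O)[C@H](O)[C@H]2O)OC=C(C(=O)OC)[C@H]1CC(=O)OCCC` also reaches only a limit, > 15000 nM. The one step between measured neighbours, a step that the two limits leave unreadable from compound 1 to compound 2, cannot be read, since both ends are limits, so compound 2 stands at the edge of what this assay can report and no stronger than any other compound shown.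

Compound 4 `C#CCOC(=O)C[C@@H]1C(C(=O)OC)=CO[C@@H](O[C@@H]2O[C@H](COC(C)=O)[C@@H](OC(C)=O)[C@H](OC(C)=O)[C@H]2OC(C)=O)/C1=C/C` differs from compound 2 by ethynyl in place of hydrogen on a saturated chain carbon bound to an oxygen next to a carbonyl group. Going by the values given here, no measured step covers a change of this kind, and every value shown is a limit. The expectation for compound 4 is therefore a result again at or beyond the limit, with the step that the limit leaves unreadable from compound 2 to compound 4 expected to be no more than scatter, giving an estimate of 20000 nM with a range from 7000 nM to 60000 nM.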

Compound 4, half-maximal inhibitory concentration: > 15000 nM
Compound 4 ended at the assay's limit; the forecaster's own chance of this, stated with the estimate: 80%; the middle value does not contradict the limit.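

Compound 2 and compound 4 both sit at a limit of this assay, and the step from hydrogen to ethynyl between them cannot be read. The compounds shown leave open whether any change to the shared core would give a true number in this assay rather than a limit.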